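The source may report more compounds than this note shows. Statements on the series, on what has been measured and on what is new or still open speak of the compounds shown alone.

Measured so far in a functional assay on cells (Platelet, Homo sapiens) for inhibition; on this read-out higher numbers stand for weaker inhibition and lower numbers for stronger inhibition:
- compound 1 `CCOC(=O)c1ccc(-c2nn(Cc3cccc(F)c3)c3ccccc23)cc1`: > 10000 nM (a limit)
- compound 2 `CC(C)OC(=O)c1ccc(-c2nn(Cc3ccccc3)c3ccccc23)cc1`: > 10000 nM (a limit)

Compound 2 gives no exact number in this assay: its > 10000 nM is a limit. Compound 1 offers no firmer reference, and the whole picture so far is the limit of > 10000 nM in this assay, at which 2 of the 2 values shown sit.

The next compound, compound 3 `CC(C)NC(=O)c1ccc(-c2nn(Cc3ccccc3)c3ccccc23)cc1`, keeps the shared core of compound 2 and has isopropylamino in place of isopropoxy on a carbonyl carbon. For the measured compounds named here, no measured pair of compounds shows what this kind of change does in this assay. The expectation is therefore cautious: a small step toward stronger inhibition at best, and quite possibly none beyond the scatter. The expected step is a number no higher from compound 2 to compound 3 (the limit leaves the size open). For compound 3 the estimated value is 10000 nM, within an expected range of 3000 nM to 30000 nM.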

Compound 3, half-maximal inhibitory concentration: > 10000 nM
Compound 3: a limit, no number; the forecaster's own chance of this, stated with the estimate: 65%; the middle value lies on the limit itself.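

Compound 2 and compound 3 each give only a limit, not a number, in this assay, so no step can be read between them: the limit of > 10000 nM in this assay, at which 3 of the 3 values shown sit.

The compounds shown leave open whether isopropylamino in place of isopropoxy on a carbonyl carbon changes inhibition at all, and what change would bring a measurable number.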